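This account rests on a few compounds, and the source may have more. Where it says the series, first, only, none or still open, it means among the compounds named here.

Measured so far in a physicochemical assay for lipophilicity, read by HPLC, at pH 7.4; on this read-out higher numbers stand for higher lipophilicity and lower numbers for lower lipophilicity: compound 1 `O=C(O)CCCOc1ccc([C@H]2CC[C@]3(CC2)OOC2(O3)C3CC4CC(C3)CC2C4)cc1` gives 3.6; compound 2 `CS(=O)(=O)NC(=O)COc1ccc([C@H]2CC[C@]3(CC2)OOC2(O3)C3CC4CC(C3)CC2C4)cc1` gives 3.

Compound 2 stands lowest of the two numbers; its nearest neighbour is compound 1, a number 0.60 log units lower from compound 1 to compound 2 (beyond the scatter).

Compound 3 `O=C(O)CCCCOc1ccc([C@H]2CC[C@]3(CC2)OOC2(O3)C3CC4CC(C3)CC2C4)cc1` is not yet measured. It differs from compound 2 as follows: 3-carboxypropyl in place of (methylsulfonyl)carbamoyl on a saturated chain carbon bound to an oxygen on an aromatic ring. Going by the values given here, the one measured step that bears on this change is a number 0.60 log units lower from compound 1 to compound 2 (beyond the scatter), which runs in the opposite direction, so a rise beyond the scatter is expected here. For compound 3 the estimated step is a number 1.00 log units higher from compound 2 to compound 3 (beyond the scatter), giving an expected value of 4, within 3.6 to 4.4.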

Compound 3, distribution coefficient: 4
Estimate against measurement, compound 3: no gap at the digits printed, within the range that was stated.
By their numbers in this assay, from the lowest: compound 2; then compound 1; then compound 3.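

With the carboxylic acid end kept and carboxymethyl in place of carboxy, this assay gives a number 0.40 log units higher from compound 1 to compound 3 (beyond the scatter), so chain length alone moves this read-out at this position. The change to 3-carboxypropyl from (methylsulfonyl)carbamoyl gives a number 1.00 log units higher from compound 2 to compound 3 (beyond the scatter), which alters end group and chain length together and spans the full range of the three compounds. No measurement offers a reason for either step.

Open, as far as these compounds go, is whether a longer chain carrying the carboxylic acid continues this rise. Also open, from the compounds shown here alone, is how an amine at the chain end would read in this assay.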